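The source may hold more compounds than are shown below. What is called first, only, known or untested is meant among the compounds shown, and "the series" means these compounds.

Compound 1 `Cc1ccc(S(=O)(=O)Oc2ccc3c(c2C)[C@H](Cn2cc(-c4ccccc4)nn2)[C@@]24CC(=O)[C@@](C)(CC[C@@H]32)C4)cc1` and compound 3 `Cc1ccc(S(=O)(=O)Oc2ccc3c(c2C)[C@H](Cn2cc(-c4ccccn4)nn2)[C@@]24CC(=O)[C@@](C)(CC[C@@H]32)C4)cc1` share a core, and compound 2 `C=C1C(=O)[C@]23C[C@@]1(O)CC[C@H]2c1ccc(O)c(C)c1[C@@H]3Cn1cc(-c2ccccc2)nn1` is built on a second core; how the two cores differ is not broken down here. In a functional assay on SMMC-7721 cells (Homo sapiens) for cytotoxicity, read by MTT assay, with a stated time of 4 days (on this read-out higher numbers stand for weaker inhibition and lower numbers for stronger inhibition), compound 1 gives a value of > 20000 nM, which is a limit of the assay and not a number. In this assay compound 3 likewise gives > 20000 nM, again a limit rather than a number. The change between them, (pyridin-2-yl in place of phenyl on an aromatic carbon), therefore leaves the step that the two limits leave unreadable from compound 1 to compound 3, because the limit of > 20000 nM in this assay, at which 2 of the 3 values shown sit, hides whatever shift it may have made. Among the measured compounds shown here, compound 2, by contrast, gives 1320 nM in this assay, the only measured number among the three.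

Compound 4 `C=C1C(=O)[C@]23C[C@@]1(O)CC[C@H]2c1ccc(O)c(C)c1[C@@H]3Cn1cc(-c2ccccn2)nn1` is not yet measured in this assay. It stands to compound 2 as compound 3 stands to compound 1: the change is pyridin-2-yl in place of phenyl on an aromatic carbon, and the place is described in the same words for both pairs, so this is the same kind of change carried onto the core of compound 2. From compound 1 to compound 3 the step could not be read, so the pair of compound 2 and compound 4 carries no measured guidance. With nothing to point either way, compound 4 is expected to sit close to compound 2, with a step of about a 1.5-fold higher number from compound 2 to compound 4 (0.18 log units; within the scatter) that rests only on compound 2 giving 1320 nM. The estimate for compound 4 in this assay is 2000 nM, expected to lie between 600 nM and 8000 nM.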

Compound 4, half-maximal inhibitory concentration: 1270 nM
Compound 4: the middle estimate sits 1.6-fold (0.20 log units) above what was measured, and the stated range covers the measured number.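

On the core of compound 2, pyridin-2-yl in place of phenyl on an aromatic carbon gives a 1.0-fold lower number from compound 2 to compound 4 (0.02 log units; within the scatter) in this assay, so compound 2 and compound 4 cannot be told apart on this read-out, even though the entering ring carries a hydrogen-bond acceptor that the leaving ring lacks. Compound 1 and compound 3 each stand at a limit of the assay and not at a number, so the same change on their core cannot be read, because any shift there stays hidden: the limit of > 20000 nM in this assay, at which 2 of the 4 values shown sit. Among the compounds shown here, the new step therefore describes this change on the core of compound 2 alone, and it does not show that the change carries from one core to the other, since only one of the two pairs can be read.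

The compounds shown leave open how an aminomethyl group, a carboxylic acid or a longer chain such as hexyl would read in place of phenyl on this aromatic carbon of the five-membered aromatic ring with 3 nitrogen on the core of compound 2. For the compounds shown here, they also leave open whether pyridin-3-yl or pyridin-4-yl would match pyridin-2-yl there, as only one ring nitrogen placement appears among them.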